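Bromo for Chloro: Expected Potency of Compound 4

The source may report more compounds than this note shows. Statements on the series, on what has been measured and on what is new or still open speak of the compounds shown alone.

Measured in a functional assay on HL-60 cells (Homo sapiens) for cytotoxicity, read by luminescence and CellTiter-Glo, with a stated time of 3 days; on this read-out higher numbers stand for weaker inhibition and lower numbers for stronger inhibition:
compound 1 `O=C(Nc1ccc(C(F)(F)F)cc1)c1cc(Cl)c(-c2ccccc2)cc1O`, 490 nM
compound 2 `O=C(Nc1ccc(Cl)c(Cl)c1)c1cc(F)ccc1O`, 660 nM
compound 3 `O=C(Nc1ccc(C(F)(F)F)cc1)c1cc(Br)c(-c2ccccc2)cc1O`, 540 nM

Compound 3 differs from compound 1 by bromo in place of chloro on an aromatic carbon, and this gave a 1.1-fold higher number from compound 1 to compound 3 (0.04 log units; within the scatter). The difference between the core of compound 1 and the core of compound 2 is not broken down here. Compound 4 `O=C(Nc1ccc(Br)c(Cl)c1)c1cc(F)ccc1O`, not yet measured, differs from compound 2 by bromo in place of chloro on an aromatic carbon. This is the same kind of change as that from compound 1 to compound 3, though its surroundings differ: there the site was ortho to a phenyl group, meta to a large group and para to a hydroxy group, here it is ortho to a chloro group and para to a large group. Because the earlier step was a 1.1-fold higher number from compound 1 to compound 3 (0.04 log units; within the scatter), compound 4 is expected to show a 1.1-fold higher number from compound 2 to compound 4 (0.03 log units; within the scatter) in this assay. Compound 4 is estimated at 700 nM, between 350 nM and 1400 nM.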

Compound 4, half-maximal inhibitory concentration: 600 nM
For compound 4 the middle estimate is 1.2-fold (0.07 log units) above the measured one; the range from low to high includes it.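

In this assay bromo in place of chloro on an aromatic carbon gave a 1.1-fold lower number from compound 2 to compound 4 (0.04 log units; within the scatter). Set beside the earlier step, the change reads alike on the two cores: the same change on two cores in this assay, a 1.1-fold higher number (0.04 log units; within the scatter) from compound 1 to compound 3 and a 1.1-fold lower number (0.04 log units; within the scatter) from compound 2 to compound 4, 1.2-fold (0.08 log units) apart, within the scatter of two such steps. This supports treating the swap as a step too small to read on both of these cores, but it gives the change no direction, and two pairs do not show that it would stay this small on another core or at another place.

The compounds shown compare only chloro and bromo at these places. From the compounds shown here alone, what an amine, a carboxylic acid or a methoxy group would do there remains open, including whether any of them would move the number beyond the scatter.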